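Cytotoxicity notes on the anilide series toward compound 4

The source may hold more compounds than are shown below. What is called first, only, known or untested is meant among the compounds shown, and "the series" means these compounds.

Measured in a toxicity assay on HepG2 cells (Homo sapiens) for inhibition, read by CellTiter-Glo, with a stated time of 48 h; on this read-out higher numbers stand for weaker inhibition and lower numbers for stronger inhibition:
Compound 1, `COc1ccc2nc(C)cc(OCC(=O)Nc3ccccc3)c2c1`, gives 39800 nM in this assay.
Compound 2, `COc1cccc(NC(=O)COc2cc(C)nc3ccc(OC)cc23)c1`, returns only a limit of the assay in this assay, namely > 100000 nM.
Compound 3, `COc1ccc2nc(C)cc(OCC(=O)Nc3ccc(Cl)cc3Cl)c2c1`, likewise returns only a limit in this assay, namely > 100000 nM.

Compound 3 therefore stands at the limit, and with the limit of > 100000 nM in this assay, at which 2 of the 3 values shown sit, its position against compound 2 cannot be read: a step that the two limits leave unreadable from compound 2 to compound 3. Only its separation from compound 1 is readable, an at least 2.5-fold higher number from compound 1 to compound 3 (0.40 log units; beyond the scatter).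

Compound 4, `COc1ccc2nc(C)cc(OCC(=O)Nc3c(C)cncc3C)c2c1`, differs from compound 3 in one place: 3,5-dimethylpyridin-4-yl in place of 2,4-dichlorophenyl on an amide-type nitrogen. Within the data shown here, no measured step involves a pyridinyl group on the amide nitrogen, so the bearing of this change is indirect. The step at the same position, an at least 2.5-fold higher number from compound 1 to compound 3 (0.40 log units; beyond the scatter), moved the number from a reading up to the limit; the step at a different place, an at least 2.5-fold higher number from compound 1 to compound 2 (0.40 log units; beyond the scatter), also ended at the limit. Within this small set, every change away from compound 1 has reached the limit. Compound 4 is therefore expected to remain close to the limit, with a number no higher from compound 3 to compound 4 (the limit leaves the size open), that is no step beyond the scatter. The estimate for compound 4 in this assay is 100000 nM, with an expected range from 40000 nM to 250000 nM.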

Compound 4, half-maximal inhibitory concentration: 12600 nM
Compound 4: the middle estimate sits 7.9-fold (0.90 log units) above what was measured, and the stated range ends above it.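

At this position, the amide-type nitrogen, a change of aromatic group can also move the number down in this assay and not only up to the limit: there is a 3.2-fold lower number from compound 1 to compound 4 (0.50 log units; beyond the scatter) and so stronger inhibition with 3,5-dimethylpyridin-4-yl than with phenyl. Compared with the two substituted anilides, the same group gives an at least 7.9-fold lower number from compound 3 to compound 4 (0.89 log units; beyond the scatter) and an at least 7.9-fold lower number from compound 2 to compound 4 (0.89 log units; beyond the scatter) in the same direction. Compound 4 thus goes against the pattern of compound 2 and compound 3, where each change away from compound 1 ended at the limit, and shows that the direction of change at this nitrogen depends on which group enters.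

Going by these compounds, the step between compound 2 and compound 3 cannot be read, and the full size of the steps from those two compounds to compound 4 stays open: the limit of > 100000 nM in this assay, at which 2 of the 4 values shown sit. The compounds shown also cannot separate the contribution of the ring nitrogen from that of the two methyl groups, a question that an unsubstituted pyridin-4-yl group and a dimethylphenyl group on the same amide nitrogen would bear on directly.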